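Notes on the aryloxy series: dropping the methoxy

This account rests on a few compounds, and the source may have more. Where it says the series, first, only, none or still open, it means among the compounds named here.

Measured so far:
compound 1 `C/C(=C\COc1c(Cl)cccc1Cl)CC/C=C(\C)C1CC(=O)C(C)(C)O1` — 32.5 ug/mL
compound 2 `COc1cccc(OC/C=C(\C)CC/C=C(\C)C2CC(=O)C(C)(C)O2)c1` — 51.5 ug/mL

Among the measured compounds shown here, in a functional assay on MT4 cells (Homo sapiens) for inhibition (a lower number here means a stronger inhibitor, a higher number a weaker inhibitor), compound 2 gives the higher of the two numbers in hand, with compound 1 nearest; the only step available, a 1.6-fold higher number from compound 1 to compound 2 (0.20 log units; within the scatter), is the exchange of the whole aryl group. Compound 3 `C/C(=C\COc1ccccc1)CC/C=C(\C)C1CC(=O)C(C)(C)O1` differs from compound 2 by hydrogen in place of methoxy on an aromatic carbon. For the measured compounds named here, no measured step bears directly on removing a single substituent from the aryl ring, and the one aryl exchange on record moved the number little. The expected step of a 1.1-fold lower number from compound 2 to compound 3 (0.06 log units; within the scatter) is therefore small, with no clear direction. Compound 3 is estimated at 45 ug/mL, within 20 ug/mL to 100 ug/mL.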

Compound 3, half-maximal inhibitory concentration: 43.1 ug/mL
For compound 3 the middle estimate is 1.0-fold (0.02 log units) above the measured one; the range from low to high includes it.
By their numbers in this assay, from the lowest: compounds 1, 3 and 2 (each within the scatter of the next).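

With the methoxy gone, this assay gives a 1.2-fold lower number from compound 2 to compound 3 (0.08 log units; within the scatter) and the number does not separate the 3-methoxyphenyl and phenyl ethers. The change from 2,6-dichlorophenyl gives a 1.3-fold higher number from compound 1 to compound 3 (0.12 log units; within the scatter) and is equally unresolved, so neither the methoxy nor the two chlorines are needed to hold the number in this range. Nothing available explains this flat response.

On these data alone, whether an amine or a carboxylic acid on the aromatic ring would move the number beyond the scatter stays open. So does whether the shared core needs an aromatic ring on its ether oxygen at all.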